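A Methoxy Replaces a Methyl: Cytotoxicity Expected Unchanged

This account rests on a few compounds, and the source may have more. Where it says the series, first, only, none or still open, it means among the compounds named here.

In an ADME assay on Vero cells (Chlorocebus sabaeus) for cytotoxicity, read by MTT assay, with a stated time of 72 h (a lower number here means that less compound is tolerated, a higher number that more compound is tolerated), compound 2 `Cc1ccc(/C=C/C(=O)NCCNc2ccnc3cc(Cl)ccc23)cc1` gives 4000 nM, the higher of the two numbers recorded so far, while compound 1 `COc1cc(/C=C/C(=O)c2ccc(OCC(O)CNCCNc3ccnc4cc(Cl)ccc34)cc2)cc(OC)c1OC` gives 1910 nM, a gap beyond the usual scatter. Compound 3 `COc1ccc(/C=C/C(=O)NCCNc2ccnc3cc(Cl)ccc23)cc1` has not yet been measured. It differs from compound 2 by methoxy in place of methyl on an aromatic carbon, on an aromatic carbon of a six-membered aromatic ring of carbon only. Among the compounds with values here, no step of this kind has been measured here, so the change is expected to shift this assay by no more than the scatter. Compound 3 is therefore estimated at 4000 nM, between 2000 nM and 8000 nM. The expected step of no change at the digits printed from compound 2 to compound 3 (within the scatter) should stay within the scatter.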

Compound 3, half-maximal cytotoxic concentration: 20600 nM
Compound 3: the middle estimate sits 5.2-fold (0.71 log units) below what was measured; measured number above the stated range.
By their numbers in this assay, from the lowest: compound 1; then compound 2; then compound 3.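

In this assay, within the data shown here, the change from 4-methylphenyl to 4-methoxyphenyl gives the first step between compounds that differ in one place: a 5.2-fold higher number from compound 2 to compound 3 (0.71 log units; beyond the scatter), so more compound is tolerated with methoxy on this aromatic carbon, para to a large group. The comparison of compound 1 with compound 2 could not show that this position alone moves the number. No measurement at hand accounts for the step. On these data alone, it remains open whether an amine, a hydroxyl or an ethoxy group at the same place would move the number in the same direction. As far as these compounds go, it also remains open whether the same exchange would give a step of similar size on the core of compound 1.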